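Swapping one ring group on compound 2

The compounds below may be only part of what the source reports. "The series", "measured", "known", "first", "only" and "open" are said of these compounds alone.

Values measured in a physicochemical assay for lipophilicity, using the shake flask method, measured as octanol-water partition, at pH 7.4; on this read-out higher numbers stand for higher lipophilicity and lower numbers for lower lipophilicity:
- compound 1 `CC(C)n1cc(-c2ccnc3[nH]c(C4CCN(CC(=O)N(C)C)CC4)cc23)cnc1=O`: 0.4
- compound 2 `CCn1cc(-c2ccnc3[nH]c(C4CCN(CC(=O)N(C)C)CC4)cc23)ccc1=O`: 1.2

Of the two compounds measured, compound 2 has the higher number, 1.2. Compound 3 `COc1cc(=O)n(C)cc1-c1ccnc2[nH]c(C3CCN(CC(=O)N(C)C)CC3)cc12` has not been measured yet. It differs from compound 2 in one place: a group of 10 heavy atoms (7 carbon, 1 nitrogen, 2 oxygen; one six-membered aromatic ring with 1 hetero atom) in place of a group of 9 heavy atoms (7 carbon, 1 nitrogen, 1 oxygen; one six-membered aromatic ring with 1 hetero atom), on an aromatic carbon.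

Going by the values given here, only one measured step changes a group at this place, and that step is a number 0.80 log units higher from compound 1 to compound 2 (beyond the scatter). There compound 1, with its group of 10 heavy atoms, gives the lower number, 0.4. Compound 3 also carries a group of 10 heavy atoms, but its ring keeps 1 hetero atom, as in compound 2. A single step is a thin guide, so only a small downward move in this assay is expected, perhaps within the scatter: the estimate is a number 0.30 log units lower from compound 2 to compound 3 (within the scatter). For compound 3 the expected value is 0.9, with an estimated range from 0.4 to 1.4.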

Compound 3, distribution coefficient: 0.7
For compound 3 the middle estimate is 0.20 log units above the measured one, and the stated range covers the measured number.
By their numbers in this assay, from the lowest: compounds 1 and 3 (each within the scatter of the next); then compound 2.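

In this assay, the exchange on this aromatic carbon gives a number 0.50 log units lower from compound 2 to compound 3 (beyond the scatter) even though the ring keeps 1 hetero atom, so a lower number here does not need a second ring hetero atom. The entering group of compound 3, compared with the group of compound 1, gives a number 0.30 log units higher from compound 1 to compound 3 (within the scatter) and so cannot be told apart from it on this read-out, although their rings hold different numbers of hetero atoms. Nothing available explains why these ring groups fall where they do.

Which feature of the group of compound 3 goes with its step remains open, as the exchanged groups differ in more than one feature. Also open, going by these compounds, is what a ring group carrying an amine, a carboxylic acid or a longer chain would give in this assay on this aromatic carbon.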